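A few compounds are considered here, and "the series" means these few. Any claim that something is new, unique, unknown or untested is made for them only; others in the source may bear on it.

- compound 1 (`Clc1ccc(-c2nnc(-c3cn4ccccc4n3)o2)cc1`), value (32800 nM)
- compound 2 (`COc1cc(-c2nnc(-c3cn4ccccc4n3)o2)cc(OC)c1OC`), value (4500 nM)

In a functional assay on DU-145 cells (Homo sapiens) for antiproliferative activity, read by MTT assay, with a stated time of 48 h (on this read-out lower numbers stand for stronger inhibition and higher numbers for weaker inhibition), compound 1 has the higher of the two numbers, and its gap to compound 2 lies beyond the usual scatter. Compound 3 (`Brc1ccc(-c2nnc(-c3cn4ccccc4n3)o2)cc1`) keeps the core of compound 1 but carries bromo in place of chloro on an aromatic carbon, para to a large group (bromo in place of chloro on an aromatic carbon). For the measured compounds named here, no measured pair shows this swap, so the expectation rests on the small size of the change alone. The expected step of a 1.2-fold lower number from compound 1 to compound 3 (0.07 log units; within the scatter) is none beyond the scatter, in either direction. Compound 3 is estimated at 28000 nM with 12000 nM to 65000 nM as its range.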

Compound 3, half-maximal inhibitory concentration: > 50000 nM
Compound 3 was reported as a limit (the forecaster's own chance of this, stated with the estimate: 10%); middle value at least 1.7-fold (0.25 log units) away from the limit.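

In this assay, the result for compound 3, > 50000 nM, is a limit of the assay and not a number. Putting bromo in place of chloro gives an at least 1.5-fold higher number from compound 1 to compound 3 (0.18 log units; that floor lies within the scatter), so this swap on the aromatic carbon brings no stronger inhibition, while the true size of the step stays hidden. The reading stops short of an exact number: the limit of > 50000 nM in this assay, at which 1 of the 3 values shown sits.

Going by these compounds, whether an amine or a carboxylic acid on this same aromatic carbon would give a lower number stays open.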